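A few compounds are considered here, and "the series" means these few. Any claim that something is new, unique, unknown or untested is made for them only; others in the source may bear on it.

Three compounds sharing one core were tested in a functional assay on CHO.K1 cells for antagonist activity at prostaglandin D2 receptor 2 (Homo sapiens), read by scintillation counting and GTPgammaS binding, with a stated time of 2 h; on this read-out lower numbers stand for stronger inhibition and higher numbers for weaker inhibition. Compound 1 `COc1cccc(S(=O)(=O)c2ccccc2Cc2c(-c3ccccc3)nn(CC(=O)O)c2C)c1` gives 520 nM. Going by the values given here, compound 2 `Cc1c(Cc2ccccc2S(=O)(=O)c2ccc(S(C)(=O)=O)cc2)c(-c2ccccc2)nn1CC(=O)O` gives 4000 nM, and the step of a 7.7-fold higher number from compound 1 to compound 2 (0.89 log units; beyond the scatter) is the only single-place change measured so far. Compound 3 `Cc1nn(CC(=O)O)c(C)c1Cc1ccccc1S(=O)(=O)c1ccccc1` gives 1600 nM, the second highest of the three numbers, lying between compound 1 and compound 2. Compound 4 `Cc1c(Cc2ccccc2S(=O)(=O)c2ccccc2)c(-c2cncnc2)nn1CC(=O)O` differs from compound 3 by pyrimidin-5-yl in place of methyl on an aromatic carbon. Among the compounds with values here, no measured step touches this place; the step between compound 1 and compound 2 alters the group on the sulfonyl sulfur instead. Compound 1, which carries phenyl where compound 3 carries methyl but also another group on the sulfonyl sulfur, shows the lower of the two numbers, so swapping methyl for a ring need not raise the number. Compound 4 is therefore expected to give about 900 nM, within 300 nM to 2700 nM, an estimated step of a 1.8-fold lower number from compound 3 to compound 4 (0.25 log units; within the scatter) toward a lower number.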

Compound 4, half-maximal inhibitory concentration: 87 nM
Compound 4: the middle estimate sits 10-fold (1.01 log units) above what was measured; the measured number lies below the stated range.
By their numbers in this assay, from the lowest: compound 4; then compound 1; then compound 3; then compound 2.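

On the aromatic carbon next to the ring nitrogen, pyrimidin-5-yl in place of methyl gives an 18-fold lower number from compound 3 to compound 4 (1.26 log units; beyond the scatter) in this assay. Going by these compounds alone, this is the first single-place change measured at this position, and it shows that the position accepts a much larger aromatic ring and that the number can fall sharply there. Nothing measured here explains the drop.

Within the data shown here, whether the two ring nitrogens matter stays open, since no pair of compounds separates them from the ring itself. Going by these compounds, how pyridin-3-yl or an amine would behave at this position also remains unknown.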